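Trifluoromethyl for Chloro on an Aromatic Carbon

The source may report more compounds than this note shows. Statements on the series, on what has been measured and on what is new or still open speak of the compounds shown alone.

Measured so far:
compound 1, `CCc1ccccc1N1C(N)=NC(N)=NC1(C)C`, in an assay for inhibition of Dihydrofolate reductase (Bos taurus), at pH 6.25; on this read-out lower numbers stand for lower potency and higher numbers for higher potency (the scale is a negative logarithm): 4.02
compound 2, `CC1(C)N=C(N)N=C(N)N1c1ccccc1Cl`, in this assay: 4.86

Within the data shown here, compound 2 stands highest of the two numbers in this assay, with compound 1 as its only neighbour, the gap between them being beyond the scatter. Among the measured compounds shown here, the single measured step, a number 0.84 log units higher from compound 1 to compound 2 (beyond the scatter), came with chloro in place of ethyl on an aromatic carbon; it is modest in size.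

The next compound, compound 3, is `CC1(C)N=C(N)N=C(N)N1c1ccccc1C(F)(F)F`. Its change from compound 2 is this: trifluoromethyl in place of chloro on an aromatic carbon.

For the measured compounds named here, only the step from compound 1 to compound 2 bears on this at all, and only loosely, since it swapped an ethyl for the chloro that now leaves again. Going by the values given here, no step exchanging chloro for trifluoromethyl has been measured. Compound 3 is therefore expected to stay close to compound 2, with a step of a number 0.16 log units lower from compound 2 to compound 3 (within the scatter) in this assay, not clearly beyond the scatter in either direction. The estimate for compound 3 in this assay is 4.7, within a range from 4.1 to 5.3.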

Compound 3, logarithm of the reciprocal of the active concentration, log(1/C): 3.15
The estimate for compound 3 lay 1.55 log units above the measured number; the measured number lies below the stated range.
By their numbers in this assay, from the lowest: compound 3; then compound 1; then compound 2.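

The exchange of chloro for trifluoromethyl on this aromatic carbon gives a number 1.71 log units lower from compound 2 to compound 3 (beyond the scatter) in this assay and is the largest step seen so far, showing that this place in the series is far from indifferent to which group it carries, even with the shared core left unchanged. Trifluoromethyl also stands apart from ethyl, with a number 0.87 log units lower from compound 1 to compound 3 (beyond the scatter), so the three groups now fall in a clear order, with chloro giving the highest number, ethyl the middle one and trifluoromethyl the lowest, each gap beyond the scatter. No measurement of any property of these groups, or of how the compounds behave, accompanies these numbers, and the size of the drop therefore stays unexplained.

The three compounds leave open where other groups at this place would fall in that order, for instance bromo, methyl or methoxy, and whether any of them would pass chloro. They also leave open whether an amine or a hydroxyl here would keep the number near that of compound 2 or take it down towards that of compound 3.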